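This account rests on a few compounds, and the source may have more. Where it says the series, first, only, none or still open, it means among the compounds named here.

Compound 1 `C=C1[C@H](C)CCC[C@]1(C)CC[C@@]1(C)C=Cc2c(O)c(OC)cc(OC)c2O1` gives 0.68 ug/mL in a functional assay on KB16 cells (Homo sapiens) for cytotoxicity, read by MTT assay; on this read-out lower numbers stand for stronger inhibition and higher numbers for weaker inhibition. Compound 2 `C=C1[C@H](C)CCC[C@]1(C)CC[C@@]1(C)C=Cc2c(OC(C)=O)c(OC(C)=O)cc(OC)c2O1` gives 3.06 ug/mL in this assay. Compound 3 `C=C1[C@H](C)CCC[C@]1(C)CC[C@@]1(C)C=Cc2c(OC(C)=O)c(OC)cc(OC(C)=O)c2O1` gives only a limit, > 10 ug/mL, in this assay.

Compound 3 thus stands at the limit of > 10 ug/mL in this assay, at which 1 of the 3 values shown sits; no number is known for it, only that limit. Compound 4 `C=C1[C@H](C)CCC[C@]1(C)CC[C@@]1(C)C=Cc2c(OC(C)=O)c(OC)cc(OC)c2O1` differs from compound 3 in one place: methyl in place of acetyl on an oxygen on an aromatic ring. With that change compound 4 comes nearer in makeup to compound 1, which gives 0.68 ug/mL in this assay, than to compound 2 or compound 3. Going by the values given here, no pair differing in one place has been measured, so the size of the step rests on these three numbers alone. The step of an at least 3.3-fold lower number from compound 3 to compound 4 (0.52 log units; beyond the scatter) is expected to be downward and beyond the scatter. Compound 4 is estimated at 3 ug/mL, within 1 ug/mL to 10 ug/mL.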

Compound 4, half-maximal inhibitory concentration: 1.32 ug/mL
Estimate against measurement, compound 4: 2.3-fold (0.36 log units) above; low and high end bracket the measured number.
By their numbers in this assay, from the lowest: compounds 1 and 4 (each within the scatter of the next); then compound 2. At a limit, above all of these: compound 3.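

Methyl in place of acetyl on an oxygen on an aromatic ring now has a size, an at least 7.5-fold lower number from compound 3 to compound 4 (0.87 log units; beyond the scatter), though only as a bound. The same swap at the other oxygen gives a 2.3-fold lower number from compound 2 to compound 4 (0.37 log units; beyond the scatter), while acetyl in place of hydrogen gives a 1.9-fold higher number from compound 1 to compound 4 (0.29 log units; within the scatter), so acetyl on that oxygen is tolerated here. Compound 3 gives no number, only a limit: the limit of > 10 ug/mL in this assay, at which 1 of the 4 values shown sits.

As far as these compounds go, the true size of the step from compound 3 stays open. So does whether a longer chain such as butyryl, or an amine-bearing ester, would be tolerated on these oxygens.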